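This account rests on a few compounds, and the source may have more. Where it says the series, first, only, none or still open, it means among the compounds named here.

Measured so far in a functional assay on PC-3 cells (Homo sapiens) for cytotoxicity, read by MTT assay, with a stated time of 72 h; on this read-out higher numbers stand for weaker inhibition and lower numbers for stronger inhibition:
- compound 1 `O=C(/C=C/c1cccc(Cl)c1Cl)Nc1cc2c(Nc3ccc(F)c(Cl)c3)ncnc2cc1O[C@H]1CCOC1`: 27500 nM
- compound 2 `COc1ccc(/C=C/C(=O)Nc2cc3c(Nc4ccc(F)c(Cl)c4)ncnc3cc2O[C@H]2CCOC2)c(OC)c1`: 2760 nM
- compound 3 `COc1cc2ncnc(Nc3ccc(F)c(Cl)c3)c2cc1NC(=O)/C=C/c1ccccc1[N+](=O)[O-]`: 14300 nM

Compound 3 stands at the high end of these numbers, within the scatter of compound 1 at 27500 nM. Compound 2 at 2760 nM lies lower than both, beyond the scatter.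

The next compound, compound 4 `COc1cc2ncnc(Nc3ccc(F)c(Cl)c3)c2cc1NC(=O)/C=C/c1ccc(C#N)cc1`, keeps the core of compound 3 and changes only the aryl group on the chain: 4-cyanophenyl in place of 2-nitrophenyl on a double-bonded chain carbon bound to a double-bonded chain carbon.

Among the compounds with values here, one measured step bears on this, and only indirectly: a 10-fold lower number from compound 1 to compound 2 (1.00 log units; beyond the scatter). It is a swap of aryl groups at the same place, but it was measured on the core of compound 1 and involves neither 2-nitrophenyl nor 4-cyanophenyl. It shows that a change at this place can move the number beyond the scatter, but it gives no direction for the present swap. Within the data shown here, no measured compound carries 4-cyanophenyl.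

With no direction supported, no step beyond the scatter is expected, though the range stays wide because of a 10-fold lower number from compound 1 to compound 2 (1.00 log units; beyond the scatter). The expected step is a 1.2-fold lower number from compound 3 to compound 4 (0.08 log units; within the scatter). For compound 4 the estimated value is 12000 nM, with an expected range of 3500 nM to 40000 nM.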

Compound 4, half-maximal inhibitory concentration: "not active" (no number reported)
The entry for compound 4 holds no number; the estimate stays without a comparison.
By their numbers in this assay, from the lowest: compound 2; then compounds 3 and 1 (each within the scatter of the next).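

In this assay, within the data shown here, compound 4 is entered as "not active" without a number, so no step from compound 3 to compound 4 can be read. The compounds shown leave open how 4-cyanophenyl and 2-nitrophenyl compare numerically on this core, and whether any aryl swap here has a consistent direction. No evidence at hand bears on this result.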